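Replacing 3-methylpiperidin-1-yl with (2-anilinoethyl)amino on a carbonyl carbon

The source may report more compounds than this note shows. Statements on the series, on what has been measured and on what is new or still open speak of the compounds shown alone.

In a functional assay on BXPC-3 cells (Homo sapiens) for antiproliferative activity, read by MTT assay, with a stated time of 48 h (on this read-out lower numbers stand for stronger inhibition and higher numbers for weaker inhibition), compound 1 `Cc1c(C(=O)NCCCN(C)C)oc2ccc(N(Cc3ccc(Br)cc3)S(=O)(=O)c3ccc(Br)cc3)cc12` gives 2020 nM, compound 2 `Cc1c(C(=O)OCCCN(C)C)oc2ccc(N(Cc3ccc(Br)cc3)S(=O)(=O)c3ccc(Br)cc3)cc12` gives 24200 nM and compound 3 `Cc1c(C(=O)N2CCCC(C)C2)oc2ccc(N(Cc3ccc(Br)cc3)S(=O)(=O)c3ccc(Br)cc3)cc12` gives 16700 nM. The two higher numbers cannot be told apart, with a 1.4-fold lower number from compound 2 to compound 3 (0.16 log units; within the scatter). Compound 1 stands clear of both, with a 12-fold higher number from compound 1 to compound 2 (1.08 log units; beyond the scatter) and an 8.3-fold higher number from compound 1 to compound 3 (0.92 log units; beyond the scatter), so compound 3 belongs to the weaker pair of this small set.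

Compound 4 `Cc1c(C(=O)NCCNc2ccccc2)oc2ccc(N(Cc3ccc(Br)cc3)S(=O)(=O)c3ccc(Br)cc3)cc12` carries (2-anilinoethyl)amino in place of 3-methylpiperidin-1-yl on a carbonyl carbon. The closest guide is compound 1, which also has a substituted amino group on that carbonyl carbon and differs from compound 3 by an 8.3-fold higher number from compound 1 to compound 3 (0.92 log units; beyond the scatter). Within the data shown here, the entering group lacks the dimethylamino end of compound 1, however, and no measured compound shows what that end contributes. Only part of that gap is therefore expected to be recovered, an estimated 2.8-fold lower number from compound 3 to compound 4 (0.44 log units; beyond the scatter). For compound 4 the expected value in this assay is 6000 nM, with an estimated range of 2000 nM to 18000 nM.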

Compound 4, half-maximal inhibitory concentration: > 40000 nM
Compound 4: only a limit was reported; the forecaster's own chance of this, stated with the estimate: 3%; middle value at least 6.6-fold (0.82 log units) away from the limit.
By their numbers in this assay, from the lowest: compound 1; then compounds 3 and 2 (each within the scatter of the next). At a limit, above all of these: compound 4.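

Compound 4 is reported only as a limit: the limit of > 40000 nM in this assay, at which 1 of the 4 values shown sits. In this assay, an amide hydrogen on this carbonyl carbon is therefore not enough to keep the activity of compound 1, since anilino in place of (dimethylamino)methyl on a saturated chain carbon, two bonds along the chain from an amide-type nitrogen, gives an at least 19-fold higher number from compound 1 to compound 4 (1.29 log units; beyond the scatter). Nor does (2-anilinoethyl)amino improve on 3-methylpiperidin-1-yl, the change giving an at least 2.3-fold higher number from compound 3 to compound 4 (0.37 log units; beyond the scatter), while (2-anilinoethyl)amino in place of 3-(dimethylamino)propoxy gives an at least 1.6-fold higher number from compound 2 to compound 4 (0.21 log units; that floor lies within the scatter), which cannot be read as a real difference.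

The compounds shown leave open whether the dimethylamino end is specifically needed, or whether another amine at the end of the chain, such as a pyrrolidine or a morpholine, would serve as well. They also leave open how a longer chain carrying the dimethylamino group would compare with compound 1.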